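Carboxy to (pyrrolidin-1-yl)methyl: expected cell-growth effect

A few compounds are considered here, and "the series" means these few. Any claim that something is new, unique, unknown or untested is made for them only; others in the source may bear on it.

Working notes on the series, step from compound 3 to compound 4.

Compound 3 `Cn1ncc(Cl)c1-c1cc(C(=O)N[C@@H]2CN[C@H](CC(=O)O)C[C@H]2c2ccc(Cl)c(Cl)c2)oc1Cl` gives 5120 nM in a functional assay on OVCAR-8 cells (Homo sapiens) for antiproliferative activity; a lower number here means a stronger inhibitor, a higher number a weaker inhibitor. Among the three measured compounds this is the highest number, beyond the scatter from both others. Compound 2 `Cn1ncc(Cl)c1-c1cc(C(=O)N[C@@H]2CN[C@H](CC(=O)NC3CC3)C[C@H]2c2ccc(Cl)c(Cl)c2)oc1Cl` gives 580 nM in this assay; compound 1 `Cn1ncc(Cl)c1-c1cc(C(=O)N[C@@H]2CNCC[C@H]2c2ccc(C(F)(F)F)cc2)oc1Cl` gives 120 nM, the lowest number of the set. Within the data shown here, the only measured step that touches compound 3 is an 8.8-fold higher number from compound 2 to compound 3 (0.95 log units; beyond the scatter), which shows that what sits on that carbonyl carbon matters and that the carboxy end is the less favourable one measured.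

Compound 4 `Cn1ncc(Cl)c1-c1cc(C(=O)N[C@@H]2CN[C@H](CCN3CCCC3)C[C@H]2c2ccc(Cl)c(Cl)c2)oc1Cl` differs from compound 3 in one place: (pyrrolidin-1-yl)methyl in place of carboxy on a saturated chain carbon bound to a saturated ring carbon. Among the measured compounds shown here, no measured step covers this exchange; the nearest guide is the step from compound 2 to compound 3, which in reverse recovers most of the lost activity, and the value of compound 1, which has no such chain at all. On that basis the number for compound 4 is expected to fall well below that of compound 3, with an 11-fold lower number from compound 3 to compound 4 (1.06 log units; beyond the scatter) as the expected step. The estimate for compound 4 in this assay is 450 nM, within 120 nM to 1700 nM.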

Compound 4, half-maximal inhibitory concentration: 1840 nM
Compound 4: middle estimate off by 4.1-fold (0.61 log units), on the low side; measured number outside the range, above it.
By their numbers in this assay, from the lowest: compound 1; then compound 2; then compound 4; then compound 3.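

In this assay the exchange of carboxy for (pyrrolidin-1-yl)methyl gives a 2.8-fold lower number from compound 3 to compound 4 (0.44 log units; beyond the scatter), so a second group at this chain end, one without a carbonyl, also gives a lower number than the carboxy end. The earlier compounds shown here could not separate two non-carboxy ends, but a 3.2-fold higher number from compound 2 to compound 4 (0.50 log units; beyond the scatter) now does: among the compounds carrying this chain, the order from the lowest number is compound 2, compound 4, compound 3, with every gap beyond the scatter, so leaving the carboxy end is not enough on its own to reach the value of the cyclopropyl amide. No supporting data bear on why the three chain ends rank in this order.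

Open, as far as these compounds go, is whether a morpholine ring or a dimethylamino group in place of the pyrrolidine ring would stay near compound 4 or move towards compound 2. Equally open, from the compounds shown here alone, is whether a methyl amide, or a shorter or longer chain carrying the cyclopropyl amide or the pyrrolidine ring, would shift the number at this saturated chain carbon.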